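A smaller oxygen-linked heteroaryl replaces the sulfur-linked tetrazole

This account rests on a few compounds, and the source may have more. Where it says the series, first, only, none or still open, it means among the compounds named here.

Compound 3 `CC(C)[C@H](NC(=O)COc1cccc2ccccc12)C(=O)N[C@@H](CC(=O)O)C(=O)CSc1nnnn1-c1ccccc1` gives 153000 nM in a functional assay on Jurkat cells (Homo sapiens) for inhibition (on this read-out lower numbers stand for stronger inhibition and higher numbers for weaker inhibition), the highest of the two numbers available. Compound 1 `CC(C)[C@H](NC(=O)COc1cccc2ccccc12)C(=O)N[C@@H](CC(=O)O)C(=O)COc1cc(C(F)(F)F)n(C)n1` gives 46000 nM in this assay, and a 3.3-fold higher number from compound 1 to compound 3 (0.52 log units; beyond the scatter). Compound 2 `CCOC(=O)c1c(C)noc1OCC(=O)[C@H](CC(=O)O)NC(=O)[C@@H](NC(=O)COc1cccc2ccccc12)C(C)C` reaches only the limit > 200000 nM. Compound 4 `CC(C)[C@H](NC(=O)COc1cccc2ccccc12)C(=O)N[C@@H](CC(=O)O)C(=O)COn1nnc2ccccc21` differs from compound 3 in that (a group of 10 heavy atoms (6 carbon, 3 nitrogen, 1 oxygen; one five-membered aromatic ring with 3 hetero atoms, one six-membered aromatic ring of carbon only) in place of a group of 12 heavy atoms (7 carbon, 4 nitrogen, 1 sulfur; one five-membered aromatic ring with 4 hetero atoms, one six-membered aromatic ring of carbon only), on a saturated chain carbon bound to a carbonyl carbon). Of the measured steps, an at least 1.3-fold lower number from compound 2 to compound 3 (0.11 log units; that floor lies within the scatter) shows that one heteroaryl exchange at this position left the value little changed, while a 3.3-fold higher number from compound 1 to compound 3 (0.52 log units; beyond the scatter) shows a modest loss when the sulfur-linked group entered in place of an oxygen-linked one; compound 4 returns to an oxygen linkage. Compound 4 is therefore expected to come in near 70000 nM, with a range from 25000 nM to 200000 nM. That expectation means a 2.2-fold lower number from compound 3 to compound 4 (0.34 log units; beyond the scatter).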

Compound 4, half-maximal inhibitory concentration: > 200000 nM
Compound 4: no number, only a limit; the forecaster's own chance of this, stated with the estimate: 15%; middle value at least 2.8-fold (0.45 log units) away from the limit.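

An oxygen linkage on this saturated chain carbon does not by itself keep the level of compound 1: the change gives an at least 4.3-fold higher number from compound 1 to compound 4 (0.63 log units; beyond the scatter). Against the sulfur-linked group the result says little, with an at least 1.3-fold higher number from compound 3 to compound 4 (0.11 log units; that floor lies within the scatter), and the step from compound 2 to compound 4 cannot be read, as both values are limits. The value of compound 4 is only a limit: the limit of > 200000 nM in this assay, at which 2 of the 4 values shown sit.

Still open, going by these compounds, is whether the linking atom or the ring decides the value at this position. A 1-methyl-5-(trifluoromethyl)-1H-pyrazol-3-yl group on sulfur, or a plain phenyl ring on oxygen, would bear on that.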